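Adding a Benzyl Group to a Ring Amine Nitrogen

The source may report more compounds than this note shows. Statements on the series, on what has been measured and on what is new or still open speak of the compounds shown alone.

Of the compounds shown here, two that share a core have been measured in an assay on HEK293 cells for displacement of a labelled ligand from Neuronal acetylcholine receptor; alpha4/beta2 (Rattus norvegicus), tested at 10 uM; on this read-out lower numbers stand for stronger inhibition and higher numbers for weaker inhibition. Compound 1 `CN1CCCC(Cn2ccccc2=O)C1` gives 980 nM in this assay. Compound 2 `O=c1ccccn1CC1CCNCC1` gives 1600 nM in this assay. Of these two numbers, compound 2 has the higher one, but its gap to compound 1 lies within the usual scatter of repeated measurements, so the two compounds cannot be ranked against each other on this read-out.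

Compound 3 `O=c1ccccn1CC1CCN(Cc2ccccc2)CC1` has not yet been measured. It differs from compound 2 by benzyl in place of hydrogen on an amine nitrogen in a ring. Going by the values given here, no measured pair in this set shows a change of this kind, so the data alone do not fix the direction of the step. The expectation is a step of a 5.0-fold higher number from compound 2 to compound 3 (0.70 log units; beyond the scatter), a weakening that goes beyond the scatter. In this assay compound 3 is therefore expected to give about 8000 nM, with a likely range from 2500 nM to 30000 nM.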

Compound 3, inhibition constant: 1300 nM
Estimate against measurement, compound 3: 6.2-fold (0.79 log units) above, outside the stated range (below it).
By their numbers in this assay, from the lowest: compounds 1, 3 and 2 (each within the scatter of the next).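

In this assay, placing benzyl instead of hydrogen on the amine nitrogen in a ring gives a 1.2-fold lower number from compound 2 to compound 3 (0.09 log units; within the scatter) and so stays within the scatter. Going by these compounds alone, this is the first sign that this nitrogen can carry a group of 7 heavy atoms, including an aromatic ring of carbon, without a change that this read-out can resolve. No supporting measurement is available to explain this result.

A single substituent cannot show how far this holds, so a longer chain such as phenylethyl on the same nitrogen might give a different number. As far as these compounds go, it is also open whether a carboxylic acid or an amine on the benzyl ring would leave the number within the scatter or shift it beyond.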